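The source may hold more compounds than are shown below. What is called first, only, known or untested is meant among the compounds shown, and "the series" means these compounds.

Measured so far:
compound 1, `Cn1c(SCc2ccccc2)nnc1-c1cc([N+](=O)[O-])cc([N+](=O)[O-])c1` — > 30000 nM (a limit of the assay)
compound 2, `Cn1c(SCc2ccc(Cl)cc2)nnc1-c1cc([N+](=O)[O-])cc([N+](=O)[O-])c1` — > 30000 nM (a limit of the assay)

In an ADME assay on HepG2 cells (Homo sapiens) for cytotoxicity, with a stated time of 48 h (a lower number here means a stronger inhibitor, a higher number a weaker inhibitor), compound 1 returns > 30000 nM, which is a limit of the assay and not a number. In this assay compound 2 returns > 30000 nM, again a limit rather than a number. The step that the two limits leave unreadable from compound 1 to compound 2 therefore cannot be read. Within the data shown here, compound 2 thus stands at the limit, as does the only other value shown, (the limit of > 30000 nM in this assay, at which 2 of the 2 values shown sit).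

Compound 3, `Cn1c(SCc2ccc(Cl)c(Cl)c2)nnc1-c1cc([N+](=O)[O-])cc([N+](=O)[O-])c1`, differs from compound 2 by chloro in place of hydrogen on an aromatic carbon. Among the measured compounds shown here, the single measured step, a step that the two limits leave unreadable from compound 1 to compound 2, is a change of the same kind and left both values at the limit, so neither direction nor size can be taken from it. Compound 3 is therefore expected to remain at that limit, the estimated step that the limit leaves unreadable from compound 2 to compound 3 being none beyond the scatter. Compound 3 is estimated at 45000 nM, between 15000 nM and 150000 nM, in this assay.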

Compound 3, half-maximal inhibitory concentration: > 30000 nM
Compound 3 ended at the assay's limit; the forecaster's own chance of this, stated with the estimate: 85%; the middle value is on the limit's open side.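

Compound 3 sits at the same limit of this assay as compound 1 and compound 2, so no new step can be read among them: the limit of > 30000 nM in this assay, at which 3 of the 3 values shown sit.

The compounds shown leave open whether chloro in place of hydrogen on an aromatic carbon changes the result in this assay at all.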